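Replacing 6-methoxypyridin-3-yl with 4-ethoxyphenyl on a shared core

The source may hold more compounds than are shown below. What is called first, only, known or untested is meant among the compounds shown, and "the series" means these compounds.

In a functional assay on A2780 cells (Homo sapiens) for antiproliferative activity, read by MTT assay, with a stated time of 48 h (on this read-out lower numbers stand for stronger inhibition and higher numbers for weaker inhibition), compound 1 `COc1ccc(-c2cc3c(cn2)[nH]c(=O)n3-c2cc(OC)c(OC)c(OC)c2)cc1F` gives 730 nM, compound 2 `COc1ccc(-c2cc3c(cn2)[nH]c(=O)n3-c2cc(OC)c(OC)c(OC)c2)cc1O` gives 240 nM and compound 3 `COc1ccc(-c2cc3c(cn2)[nH]c(=O)n3-c2cc(OC)c(OC)c(OC)c2)cn1` gives 990 nM. The data show a 4.1-fold higher number from compound 2 to compound 3 (0.62 log units; beyond the scatter), so compound 3 sits on the weaker side of compound 2, while its value cannot be told apart from that of compound 1.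

Compound 4 `CCOc1ccc(-c2cc3c(cn2)[nH]c(=O)n3-c2cc(OC)c(OC)c(OC)c2)cc1` keeps the shared core and exchanges the aryl group, 4-ethoxyphenyl in place of 6-methoxypyridin-3-yl on an aromatic carbon. Going by the values given here, no measured compound carries an ethoxy group, so no step tests this change directly. The closest guide is another exchange of the same aryl group, a 1.4-fold higher number from compound 1 to compound 3 (0.13 log units; within the scatter), which stayed within the scatter. Among the compounds with values here, the only other step that starts from compound 1, a 3.0-fold lower number from compound 1 to compound 2 (0.48 log units; beyond the scatter), depends on a hydroxy group that compound 4 lacks, so it offers little guidance here. A shift beyond the scatter is therefore not expected in this assay, although the untested ethoxy group leaves the range wide.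

The expected change is a 1.4-fold lower number from compound 3 to compound 4 (0.15 log units; within the scatter). For compound 4 the estimated value is 700 nM, with an expected range from 220 nM to 2300 nM.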

Compound 4, half-maximal inhibitory concentration: 2980 nM
Estimate against measurement, compound 4: 4.3-fold (0.63 log units) below; the measured number lies above the stated range.
By their numbers in this assay, from the lowest: compound 2; then compounds 1 and 3 (each within the scatter of the next); then compound 4.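

In this assay the aryl group at this place proves less forgiving than compound 1 and compound 3 suggested, since their values could not be told apart, whereas a 3.0-fold higher number from compound 3 to compound 4 (0.48 log units; beyond the scatter) lies beyond the scatter. The same holds against the two phenyl compounds, with a 4.1-fold higher number from compound 1 to compound 4 (0.61 log units; beyond the scatter) and a 12-fold higher number from compound 2 to compound 4 (1.09 log units; beyond the scatter) as the largest step in the set, which leaves compound 4 as the weakest of the four. Going by these compounds alone, all three earlier compounds carry a methoxy group on this aryl ring and compound 4 alone carries an ethoxy group, so the exchange for 4-ethoxyphenyl costs activity against each of them, with no compound here going against that.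

No measurement given here accounts for the loss. As far as these compounds go, each step also changes more than one feature of the aryl group, so the ethoxy chain cannot be separated from the missing ring nitrogen, fluoro or hydroxy, and a plain 4-methoxyphenyl group would be the direct test, while an amine in place of the hydroxy of compound 2 remains open as well.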